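Swapping the thiazole for an oxadiazole isomer

A few compounds are considered here, and "the series" means these few. Any claim that something is new, unique, unknown or untested is made for them only; others in the source may bear on it.

Compound 1 `Cc1nc(-c2ccccc2NCC2=NCCN2)cs1`: 69.2 nM
Compound 2 `Cc1noc(-c2ccccc2NCC2=NCCN2)n1`: < 5020 nM

For the measured compounds named here, compound 1 carries a 2-methyl-1,3-thiazol-4-yl group on its core and is the only compound here with a plain number in a functional assay for activation of Alpha-1B adrenergic receptor (Homo sapiens), read by calcium flux; a lower number here means that less compound is needed, a higher number that more compound is needed for the effect. Compound 2, its 3-methyl-1,2,4-oxadiazol-5-yl analogue, gives only a limit of the assay, < 5020 nM, so the step that the limit leaves unreadable from compound 1 to compound 2 cannot be sized (the limit of < 5020 nM in this assay, at which 1 of the 2 values shown sits). Compound 3 `Cc1nc(-c2ccccc2NCC2=NCCN2)no1` carries the other oxadiazole isomer; the change from compound 1 is 5-methyl-1,2,4-oxadiazol-3-yl in place of 2-methyl-1,3-thiazol-4-yl on an aromatic carbon. Going by the values given here, no measured step tells how large a move this brings in this assay, so the expectation rests on the nearest analogue only. Compound 3 is expected to need more compound than compound 1, with a step of roughly an 8.7-fold higher number from compound 1 to compound 3 (0.94 log units; beyond the scatter). The estimate for compound 3 is 600 nM, within 100 nM to 4000 nM.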

Compound 3, half-maximal effective concentration: 676 nM
Compound 3: the middle estimate sits 1.1-fold (0.05 log units) below what was measured; the measured number falls inside the stated range.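

For the compounds shown here, for the first time, a size can be put on moving away from the thiazole at this position: in this assay, 5-methyl-1,2,4-oxadiazol-3-yl in place of 2-methyl-1,3-thiazol-4-yl gives a 9.8-fold higher number from compound 1 to compound 3 (0.99 log units; beyond the scatter). Compound 3 still gives a plain number, so a compound with this oxadiazole on an aromatic carbon keeps a measurable effect, although more compound is needed. The value of compound 2 is a limit, so the steps that involve it cannot be read and the two oxadiazole isomers cannot be ranked: the limit of < 5020 nM in this assay, at which 1 of the 3 values shown sits.

No compound shown separates the loss of sulfur from the gain of a further ring nitrogen, so it stays open which of these goes with the step. Also open, from the compounds shown here alone, is how a group of another kind here, such as an amine, a carboxylic acid or a plain phenyl ring, would behave in this assay.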